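Series notes: guanidine-urea H2 ligands, aryl to cyclohexyl

The source may hold more compounds than are shown below. What is called first, only, known or untested is meant among the compounds shown, and "the series" means these compounds.

Measured compounds:
- compound 1 `Cc1nc(N)sc1CCCN/C(N)=N/C(=O)NCC(C)CCc1ccccc1`: 63.1 nM
- compound 2 `CCCCCCNC(=O)/N=C(\N)Nc1cccc(-c2csc(N)n2)c1`: 692 nM
- compound 3 `Cc1nc(N)sc1CCCN/C(N)=N/C(=O)NC(C)c1ccccc1F`: 28.8 nM

In an assay on membranes from Sf9 cells for displacement of a labelled ligand from histamine H2 receptor (Homo sapiens), read by scintillation counting, with a stated time of 60 min (a lower number here means a stronger inhibitor, a higher number a weaker inhibitor), compound 1 gives 63.1 nM. Of the three numbers this is the second highest. Compound 3 gives a lower number, and the gap lies beyond the scatter of repeats; compound 2 gives a higher number, with a wider gap, also beyond the scatter. Among the compounds with values here, no step between two measured compounds that differ in one place is available, so the series gives no direct read on any single change.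

Compound 4 `Cc1nc(N)sc1CCCN/C(N)=N/C(=O)NCC(C)CC1CCCCC1` is not yet measured. Against compound 1 the change is cyclohexyl in place of benzyl on a saturated chain carbon, three bonds along the chain from an amide-type nitrogen. Nothing among compounds 1 to 3 isolates this kind of exchange, so the expectation rests on the unchanged shared core and the small size of the change. The step from compound 1 to compound 4 in this assay is expected to be a 1.1-fold lower number from compound 1 to compound 4 (0.02 log units; within the scatter), that is, no shift beyond the scatter in either direction. Compound 4 is therefore estimated at 60 nM, within a range of 20 nM to 200 nM.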

Compound 4, inhibition constant: 70.8 nM
For compound 4 the middle estimate is 1.2-fold (0.07 log units) below the measured one, and the stated range covers the measured number.
By their numbers in this assay, from the lowest: compound 3; then compounds 1 and 4 (each within the scatter of the next); then compound 2.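

In this assay, cyclohexyl in place of benzyl on a saturated chain carbon, three bonds along the chain from an amide-type nitrogen, gives a 1.1-fold higher number from compound 1 to compound 4 (0.05 log units; within the scatter). Within the data shown here, this is the first step that isolates one change, and at this position the assay does not separate the six-membered aromatic ring from the non-aromatic one, on this shared core and in this single pair. No measurement at hand bears on why the two compounds read alike.

Still open, as far as these compounds go, is how an amine or a carboxylic acid on the cyclohexyl ring, or a longer chain carrying that ring, would read at this position. The compounds shown also leave open whether the same exchange reads alike in any other pair of the series.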